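The source may report more compounds than this note shows. Statements on the series, on what has been measured and on what is new or still open speak of the compounds shown alone.

Among the compounds with values here, in a functional assay on Jurkat cells (Homo sapiens) (on this read-out lower numbers stand for stronger inhibition and higher numbers for weaker inhibition), two compounds sharing the same core have numbers so far. Compound 1 `C[C@H](NC(=O)C(=O)Nc1cccnc1N(C)C)C(=O)N[C@@H](CC(=O)O)C(=O)COc1c(F)c(F)cc(F)c1F` gives 27 nM, and compound 2 `C[C@H](NC(=O)C(=O)NCc1cc(Cl)ccc1Cl)C(=O)N[C@@H](CC(=O)O)C(=O)COc1c(F)c(F)cc(F)c1F` gives 4.3 nM. That is the lower of the two numbers, and so the stronger inhibition, by a margin beyond the usual scatter of repeated measurements.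

The next compound, compound 3 `C[C@H](NC(=O)C(=O)NCc1cc(F)cc(F)c1)C(=O)N[C@@H](CC(=O)O)C(=O)COc1c(F)c(F)cc(F)c1F`, differs from compound 2 in one group: 3,5-difluorophenyl in place of 2,5-dichlorophenyl on a saturated chain carbon bound to an amide-type nitrogen. Put another way, 2,5-dichlorobenzyl becomes 3,5-difluorobenzyl.

Within the data shown here, only one measured step bears on this change. It is a 6.3-fold lower number from compound 1 to compound 2 (0.80 log units; beyond the scatter), which came with 2,5-dichlorobenzyl in place of 2-(dimethylamino)pyridin-3-yl on an amide-type nitrogen. Among the measured compounds shown here, that step shows that a change of this group can move the number, but no measured pair compares one benzyl group with another. The new group is still a benzyl group, so a smaller step than that one is expected, with a modest lean towards a higher number.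

The expected change is a 1.9-fold higher number from compound 2 to compound 3 (0.27 log units; within the scatter). Compound 3 is estimated at 8 nM, with an expected range of 2.5 nM to 25 nM.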

Compound 3, half-maximal inhibitory concentration: 16 nM
For compound 3 the middle estimate is 2.0-fold (0.30 log units) below the measured one; the measured number falls inside the stated range.
By their numbers in this assay, from the lowest: compound 2; then compounds 3 and 1 (each within the scatter of the next).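

In this assay, exchanging one benzyl group for another is not a neutral change: the step is a 3.7-fold higher number from compound 2 to compound 3 (0.57 log units; beyond the scatter), even though both groups count the same heavy atoms and the same kind of aromatic ring. The result also alters the picture from the earlier comparison, because the other step is a 1.7-fold lower number from compound 1 to compound 3 (0.23 log units; within the scatter), so 3,5-difluorobenzyl cannot be told apart from 2-(dimethylamino)pyridin-3-yl here, and the clear advantage belongs to 2,5-dichlorobenzyl rather than to benzyl groups as a whole. No measurement is available that would explain the difference between the two benzyl groups.

The change from 2,5-dichlorobenzyl to 3,5-difluorobenzyl alters both the halogen and the numbers in the group's name, so these compounds cannot show which of the two matters; 2,5-difluorobenzyl or 3,5-dichlorobenzyl would separate them. An unsubstituted benzyl group is also absent from the compounds shown, which leaves open how much either pair of halogens contributes compared with no halogen at all.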